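Swapping the Sulfonyl Aryl Group in a Weakly Active Series

The compounds below may be only part of what the source reports. "The series", "measured", "known", "first", "only" and "open" are said of these compounds alone.

Compound 1 `O=S(=O)(Nc1ccc2oc(-c3ccccc3)nc2c1)c1ccc(Cl)c(Cl)c1` is a sulfonamide. In an assay on isolated protein for inhibition of malate dehydrogenase, mitochondrial (Sus scrofa), with stated times of 45 min and 30 min (on this read-out higher numbers stand for weaker inhibition and lower numbers for stronger inhibition), compound 1 gives > 63000 nM, which is a limit of the assay rather than a number. Compound 2 `Cc1ccccc1S(=O)(=O)Nc1ccc(-c2nc3ccccc3o2)cc1` gives > 63000 nM, also a limit. Compound 3 `O=S(=O)(Nc1ccc2oc(-c3ccccc3)nc2c1)c1ccc(Cl)c(C(F)(F)F)c1` gives > 63000 nM, again a limit. The step that the two limits leave unreadable from compound 1 to compound 3 is the only one measured, and its size cannot be read, since every value shown sits at the limit of > 63000 nM in this assay, at which 3 of the 3 values shown sit. Compound 4 `Cc1cccc(S(=O)(=O)Nc2ccc3oc(-c4ccccc4)nc3c2)c1` differs from compound 1 in one place: 3-methylphenyl in place of 3,4-dichlorophenyl on a sulfonyl sulfur. No readable measured step bears on this change, so no direction beyond the scatter is expected. Compound 4 is therefore expected to give about 100000 nM, between 30000 nM and 300000 nM. The step that the limit leaves unreadable from compound 1 to compound 4 is thus an estimate, not a measurement.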

Compound 4, half-maximal inhibitory concentration: > 63000 nM
Compound 4: only a limit was reported (the forecaster's own chance of this, stated with the estimate: 85%); the middle value does not contradict the limit.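

Compound 1 and compound 4 both give only a limit, so no step between them can be read: the limit of > 63000 nM in this assay, at which 4 of the 4 values shown sit.

The compounds shown leave open how far any of these sulfonyl aryl groups changes inhibition in this assay.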